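Trading a bromophenyl ring for a short chain

The source may report more compounds than this note shows. Statements on the series, on what has been measured and on what is new or still open speak of the compounds shown alone.

Measured compounds:
compound 1, `OC[C@H]1O[C@@H](n2cnc3c(SCC4CCCCC4)ncnc32)[C@H](O)[C@@H]1O`, 1550 nM
compound 2, `Nc1nc(SCc2cccc(Br)c2)c2ncn([C@@H]3O[C@H](CO)[C@@H](O)[C@H]3O)c2n1`, 2880 nM
compound 3, `Nc1nc(SCc2ccc(Br)cc2)c2ncn([C@@H]3O[C@H](CO)[C@@H](O)[C@H]3O)c2n1`, 813 nM

The three measured compounds were all tested in an assay on isolated protein for binding affinity to Equilibrative nucleoside transporter 1 (Homo sapiens); on this read-out higher numbers stand for weaker inhibition and lower numbers for stronger inhibition. Compound 3 gives the lowest of the three numbers, but its gap to compound 1 is within the usual scatter, so the two cannot be ranked against each other; only compound 2 stands clearly apart. Among the measured compounds shown here, compound 1 differs from compound 3 in more than one place, so its value offers no single step to read. For the measured compounds named here, the one clean step is a 3.5-fold lower number from compound 2 to compound 3 (0.55 log units; beyond the scatter), showing that moving the bromine around the ring matters to a modest degree.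

Compound 4, `CCCCSc1nc(N)nc2c1ncn2[C@@H]1O[C@H](CO)[C@@H](O)[C@H]1O`, is compound 3 with propyl in place of 4-bromophenyl on a saturated chain carbon bound to a sulfur. Going by the values given here, no measured step covers removing the aromatic ring altogether, so the expectation leans only on the size of the one step seen. Since that step was modest, and the ring is lost rather than shifted, a modest move toward a higher number is expected, as a 3.1-fold higher number from compound 3 to compound 4 (0.49 log units; beyond the scatter). Compound 4 is therefore estimated at 2500 nM, with a range from 800 nM to 8000 nM.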

Compound 4, half-maximal inhibitory concentration: 12000 nM
Compound 4: middle estimate off by 4.8-fold (0.68 log units), on the low side; the whole stated range lies below it.
By their numbers in this assay, from the lowest: compounds 3, 1 and 2 (each within the scatter of the next, the first and the last beyond it); then compound 4.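

Among the compounds shown here, until now the only change seen at this position was a shift of the bromine around the ring, and that left the aromatic ring in place. Replacing the whole 4-bromobenzyl group on the sulfur with butyl is a more costly change, giving a 15-fold higher number from compound 3 to compound 4 (1.17 log units; beyond the scatter) and, starting from the 3-bromophenyl compound, a 4.2-fold higher number from compound 2 to compound 4 (0.62 log units; beyond the scatter) so both bromine-bearing compounds keep lower numbers than the plain chain, wherever the bromine sits, and the size of the loss depends on which of the two is the starting point. Nothing available here explains why the chain fares worse than either ring-bearing group.

These compounds cannot separate the contribution of the ring from that of its bromine, and a plain benzyl group on the sulfur, carrying the ring without the halogen, would divide the two. A longer chain such as hexyl in place of butyl would show whether more carbon alone can bring the number back down, or whether an aromatic ring is needed at this position.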